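The source may hold more compounds than are shown below. What is called first, only, known or untested is meant among the compounds shown, and "the series" means these compounds.

Two related compounds have been measured so far in an ADME assay on MT4 cells (Homo sapiens) for cytotoxicity, read by XTT assay, with a stated time of 3 days; a higher number here means that more compound is tolerated, a lower number that less compound is tolerated. Compound 1 `O=c1[nH]c(=O)n(COCc2ccccc2)c(Cc2ccccc2)c1I` gives 74800 nM, and compound 2 `CCOCn1c(Cc2ccccc2)c(Br)c(=O)[nH]c1=O` gives 155000 nM. Compound 2 therefore holds the higher of the two numbers, and its gap to compound 1 lies just beyond the usual scatter.

Compound 3 `O=c1[nH]c(=O)n(COCc2ccccc2)c(Cc2ccccc2)c1Br` has not yet been measured. It differs from compound 2 by a single change: phenyl in place of methyl on a saturated chain carbon bound to an oxygen on a saturated carbon. This turns ethoxy into benzyloxy. For the measured compounds named here, no measured pair shows this change on its own, so its effect cannot be read directly from the data. Going by the values given here, the only guide is that compound 1 also carries benzyloxy and sits at 74800 nM. On that thin basis, a modest move towards a lower number in this assay is expected, one that may stay within the scatter. The expected change is a 1.7-fold lower number from compound 2 to compound 3 (0.24 log units; within the scatter). For compound 3 the estimated value is 90000 nM, with an expected range from 40000 nM to 170000 nM.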

Compound 3, half-maximal cytotoxic concentration: 67400 nM
Compound 3: the middle estimate sits 1.3-fold (0.13 log units) above what was measured; the range from low to high includes it.
By their numbers in this assay, from the lowest: compounds 3 and 1 (each within the scatter of the next); then compound 2.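

In this assay, for the compounds shown here, phenyl in place of methyl on a saturated chain carbon bound to an oxygen on a saturated carbon gives a 2.3-fold lower number from compound 2 to compound 3 (0.36 log units; beyond the scatter) and so provides the first direct reading of ethoxy to benzyloxy on its own, with bromo held constant on the aromatic carbon. The halogen step, bromo in place of iodo on an aromatic carbon, gives a 1.1-fold lower number from compound 1 to compound 3 (0.05 log units; within the scatter) when benzyloxy is held constant, so among these compounds the chain change is the step that clears the usual scatter, while the halogen step does not. No measurement shown here explains why either step has the size it has.

This single chain step cannot show whether the number falls steadily as the group grows, so a propyl chain or a butyl chain would be needed to tell whether size alone follows the same direction, and a phenyl ring carrying an amine or a carboxylic acid would test how much the ring itself can tolerate. As far as these compounds go, it also remains open whether ethoxy to benzyloxy gives a similar step when iodo or chloro replaces bromo on the aromatic carbon.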